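A few compounds are considered here, and "the series" means these few. Any claim that something is new, unique, unknown or untested is made for them only; others in the source may bear on it.

Of the compounds shown here, three sharing one core have been tested in an assay on isolated protein for inhibition of kallikrein-7 (Mus musculus), read by fluorescence, with stated times of 10 min and 30 min; a lower number here means a stronger inhibitor, a higher number a weaker inhibitor. Compound 1 `CC1=NC(c2cn(S(=O)(=O)c3ccccc3)c3ccc(C)cc23)CN1` gives 15000 nM in this assay. Compound 2 `CC1=NC(c2cn(S(=O)(=O)c3ccc(F)cc3)c3ccc(C)cc23)CN1` reaches only a limit of this assay, > 30000 nM. Compound 3 `CC1=NC(c2cn(S(=O)(=O)c3cccc(Cl)c3)c3ccc(C)cc23)CN1` gives 10000 nM, the lower of the two numbers shown, although its separation from compound 1 stays within the usual scatter: a 1.5-fold lower number from compound 1 to compound 3 (0.18 log units; within the scatter). The step from the limit was larger: an at least 3.0-fold lower number from compound 2 to compound 3 (0.47 log units; beyond the scatter). Compound 4 `CC1=NC(c2cn(S(=O)(=O)c3ccccc3C#N)c3ccc(C)cc23)CN1` differs from compound 3 in one place: 2-cyanophenyl in place of 3-chlorophenyl on a sulfonyl sulfur. The measured steps on this ring were either within the scatter or started from a limit, so no change beyond the scatter is expected in this assay, a 1.2-fold higher number from compound 3 to compound 4 (0.08 log units; within the scatter). Compound 4 is therefore estimated at 12000 nM, within 4000 nM to 30000 nM.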

Compound 4, half-maximal inhibitory concentration: 11000 nM
For compound 4 the middle estimate is 1.1-fold (0.04 log units) above the measured one; measured number inside the range.
By their numbers in this assay, from the lowest: compounds 3, 4 and 1 (each within the scatter of the next). At a limit, above all of these: compound 2.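

Placing 2-cyanophenyl on the sulfonyl sulfur leaves the number within the scatter of both neighbours: a 1.1-fold higher number from compound 3 to compound 4 (0.04 log units; within the scatter), and a 1.4-fold lower number from compound 1 to compound 4 (0.13 log units; within the scatter). A nitrile therefore joins chloro as a second group on this ring that produces no change beyond the scatter relative to plain phenyl. The one step beyond the scatter, an at least 2.7-fold lower number from compound 2 to compound 4 (0.43 log units; beyond the scatter), starts from a limit, not a number: the limit of > 30000 nM in this assay, at which 1 of the 4 values shown sits.

From the compounds shown here alone, whether an amine or a carboxylic acid on this ring would give a number clearly lower than these remains open. So does the effect of moving the nitrile elsewhere on the ring.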